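The compounds below may be only part of what the source reports. "The series", "measured", "known", "first", "only" and "open" are said of these compounds alone.

Measured so far:
- compound 1, `C/N=C(\S)CCn1nc(-c2ccccc2)ccc1=O`: 68.2%
- compound 2, `CC(CC(=N)S)n1nc(-c2ccccc2)ccc1=O`: 15.5%
- compound 3, `C/N=C(\S)CCn1ncccc1=O`: 35.7%

In a functional assay on the whole organism (stomach) for inhibition, with Rattus norvegicus as the target, at a dose of 100 mg/kg by the intraduodenal route (on this read-out lower numbers stand for less inhibition and higher numbers for more inhibition at the one dose given (going by the name of the read-out)), compound 1 gives the highest of the three numbers; compound 3 comes nearest and compound 2 lies furthest away. The two measured steps that start from compound 1 both run downward and both go beyond the scatter: a number 52.7 percentage points lower from compound 1 to compound 2 (beyond the scatter) when the group on the aromatic nitrogen is exchanged for another of the same size, and a number 32.5 percentage points lower from compound 1 to compound 3 (beyond the scatter) when phenyl on the aromatic carbon is replaced by hydrogen.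

Compound 4, `N=C(S)CCCCCCn1nc(-c2ccccc2)ccc1=O`, keeps the phenyl of compound 1 and alters the chain instead: a group of 7 heavy atoms (5 carbon, 1 nitrogen, 1 sulfur; no ring) in place of a group of 4 heavy atoms (2 carbon, 1 nitrogen, 1 sulfur; no ring), on a saturated chain carbon, two bonds along the chain from an aromatic nitrogen. Of the measured steps, the one that bears on this change is that from compound 1 to compound 2, since there too the chain-bound group was reworked while the core and the phenyl were left in place, and that step was large and downward. The step to compound 3 is less relevant here. In compound 4 the phenyl stays. A downward step beyond the scatter is therefore expected in this assay, though its size is uncertain since the entering group is larger and differs in kind from that of compound 2.

For compound 4 the expected value in this assay is 35% (range 10% to 62%), which means an expected step of a number 33.2 percentage points lower from compound 1 to compound 4 (beyond the scatter).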

Compound 4, a percentage reported as inhibition, in the whole organism at one dose (the size of the read-out at that dose, not a potency): 33.9%
For compound 4 the middle estimate is 1.1 percentage points above the measured one; low and high end bracket the measured number.
By their numbers in this assay, from the lowest: compound 2; then compounds 4 and 3 (each within the scatter of the next); then compound 1.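

In this assay, placing the group of 7 heavy atoms (5 carbon, 1 nitrogen, 1 sulfur; no ring) on the saturated chain carbon, two bonds along the chain from an aromatic nitrogen, gives a number 34.3 percentage points lower from compound 1 to compound 4 (beyond the scatter), so keeping the phenyl and the shared core does not by itself preserve the number seen for compound 1. Together with a number 52.7 percentage points lower from compound 1 to compound 2 (beyond the scatter), this makes two different reworkings of the chain-bound group that both run downward with the phenyl in place, and no chain change shown here goes against that direction. No measured evidence on the compounds shown accounts for this loss.

The entering group differs from the leaving one both in size and in carrying 2 hydrogen-bond donors in place of 1 hydrogen-bond donor, so this single step does not separate the contributions of those differences. From the compounds shown here alone, how a longer chain, an amine or a carboxylic acid at this place would read in this assay remains open, as does whether any such group could match or exceed compound 1.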